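The source may report more compounds than this note shows. Statements on the series, on what has been measured and on what is new or still open speak of the compounds shown alone.

Working notes on the series.

Compound 1 `N=C(N)c1ccc(C(=O)NCCC[C@H]2C(=O)N(CC(=O)O)CCN2C(=O)CNC(=O)c2ccc(C(=N)N)cc2)cc1` is the reference point. Within the data shown here, in a functional assay for inhibition, with Cavia porcellus as the target (a lower number here means a stronger inhibitor, a higher number a weaker inhibitor), compound 1 gives 37 nM, the lowest of the three numbers so far. Compound 3 `N=C(N)Nc1ccc(C(=O)NCC[C@H]2C(=O)N(CC(=O)O)CCN2C(=O)CNC(=O)c2ccc(NC(=N)N)cc2)cc1` comes nearest, giving 97 nM in this assay, a gap beyond the scatter. Compound 2 `N=C(N)c1ccc(C(=O)NCCCC[C@H]2C(=O)N(CC(=O)O)CCN2C(=O)CNC(=O)c2ccc(C(=N)N)cc2)cc1` is furthest, giving 150 nM in this assay, also beyond the scatter. Neither of these two pairs with compound 1 differs in a single place, so the numbers are taken only as they stand.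

The step under consideration leads to compound 4 `N=C(N)Nc1ccc(C(=O)NCCC[C@H]2C(=O)N(CC(=O)O)CCN2C(=O)CNC(=O)c2ccc(C(=N)N)cc2)cc1`. Relative to compound 1 the change is a group of 4 heavy atoms (1 carbon, 3 nitrogen; no ring) in place of a group of 3 heavy atoms (1 carbon, 2 nitrogen; no ring), on an aromatic carbon. Among the measured compounds shown here, no measured pair shows this exchange alone; compound 3 carries the larger group at both ends together with a shorter chain, which leaves the contribution of the exchange itself open.

The expected step from compound 1 to compound 4 in this assay is a small weakening, a 1.6-fold higher number from compound 1 to compound 4 (0.21 log units; within the scatter), at the edge of the scatter. For compound 4 the estimate in this assay is 60 nM, with a range from 25 nM to 150 nM.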

Compound 4, half-maximal inhibitory concentration: 19 nM
The estimate for compound 4 lay 3.2-fold (0.50 log units) above the measured number; the whole stated range lies above it.
By their numbers in this assay, from the lowest: compounds 4 and 1 (each within the scatter of the next); then compounds 3 and 2 (each within the scatter of the next).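

Among these compounds, the exchange now stands alone for the first time: on an aromatic carbon of a six-membered aromatic ring of carbon only, para to a large group, a group of 4 heavy atoms (1 carbon, 3 nitrogen; no ring) in place of a group of 3 heavy atoms (1 carbon, 2 nitrogen; no ring) gives a 1.9-fold lower number from compound 1 to compound 4 (0.29 log units; within the scatter) in this assay. At this position the two groups therefore cannot be told apart in this assay, something compound 3 could not show, as it differs from compound 1 in more than one place. Nothing measured on these compounds bears on why the step has this size.

Still open, as far as these compounds go, is whether the same exchange on the other aromatic ring of the shared core, alone or together with this one at the same chain length, also stays within the scatter. Equally open, from the compounds shown here alone, is how a simple amine or an aminomethyl group at this position would read in this assay, since both groups seen here carry 1 carbon and at least 2 nitrogen atoms.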